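Five-membered rings in place of pyridin-3-yl

This account rests on a few compounds, and the source may have more. Where it says the series, first, only, none or still open, it means among the compounds named here.

Compound 1, `c1cncc(-c2ccccc2OCC2=NCCN2)c1`, is the point of reference. In a functional assay for activation of Alpha-1D adrenergic receptor (Homo sapiens), read by calcium flux (on this read-out higher numbers stand for an effect only at larger amounts of compound and lower numbers for an effect already at smaller amounts), compound 1 gives 158 nM, the highest of the two numbers shown; the nearest number is that of compound 3. Compound 3, `c1ccc(-c2ccoc2)c(OCC2=NCCN2)c1`, carries furan-3-yl in place of pyridin-3-yl and in this assay gives 5.01 nM; the step is a 32-fold lower number from compound 1 to compound 3 (1.50 log units; beyond the scatter). Compound 2, `c1ccc(-c2ccncn2)c(OCC2=NCCN2)c1`, carries pyrimidin-4-yl; in this assay compound 2 shows only a limit, < 100000 nM. Because of the limit of < 100000 nM in this assay, at which 1 of the 3 values shown sits, the steps to and from compound 2 cannot be sized: a step that the limit leaves unreadable from compound 1 to compound 2 and a step that the limit leaves unreadable from compound 2 to compound 3.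

Compound 4, `c1ccc(-c2cc[nH]n2)c(OCC2=NCCN2)c1`, is still to be measured. Its change from compound 1 is 1H-pyrazol-3-yl in place of pyridin-3-yl on an aromatic carbon. Only the readable step from compound 1 to compound 3 bears on it: there too a six-membered aromatic ring with one hetero atom gave way to a five-membered aromatic ring, and the number fell by a large amount. The entering ring here differs from furan-3-yl in carrying two hetero atoms and one hydrogen-bond donor, so the transfer is uncertain. A lower number than for compound 1 is expected, but a smaller step than to compound 3: compound 4 is estimated at 30 nM, between 5 nM and 200 nM, which means an expected step of a 5.3-fold lower number from compound 1 to compound 4 (0.72 log units; beyond the scatter).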

Compound 4, half-maximal effective concentration: < 100000 nM
Compound 4: a limit, no number (the forecaster's own chance of this, stated with the estimate: 5%); the middle value lies beyond the limit too.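

Going by these compounds alone, no step between compound 4 and compound 1, compound 2 or compound 3 can be read in this assay, since compound 4 gives a limit and no number: the limit of < 100000 nM in this assay, at which 2 of the 4 values shown sit.

The compounds shown leave open how far compound 2 and compound 4 lie from compound 1, and whether a five-membered aromatic ring other than furan-3-yl gives a readable number.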